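A few compounds are considered here, and "the series" means these few. Any claim that something is new, unique, unknown or untested is made for them only; others in the source may bear on it.

Measured compounds:
- compound 1, `COc1ccc(/C=C\C(=O)O)c(OCc2cn(-c3cccc(C#N)c3)nn2)c1CC=C(C)C`: in a functional assay on A549 cells (Homo sapiens) for cytotoxicity, read by MTT assay, with a stated time of 24 h (on this read-out lower numbers stand for stronger inhibition and higher numbers for weaker inhibition), compound 1 gives "not determined" (no result reported)
- compound 2, `COc1ccc(/C=C\C(=O)O)c(OCc2cn(-c3ccc(C#N)cc3)nn2)c1CC=C(C)C`: in this assay compound 2 gives 42200 nM

Among the measured compounds shown here, compound 2 carries the only number; compound 1, with the nitrile moved on the phenyl, has no value, so nothing can be read from the pair. Compound 2 stands on its own, and its value marks weak cytotoxicity on this read-out.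

Compound 3, `COc1ccc(/C=C\C(=O)O)c(OCc2cn(-c3ccccc3C#N)nn2)c1CC=C(C)C`, is the remaining isomer: 2-cyanophenyl in place of 4-cyanophenyl on an aromatic nitrogen. The two share every other part of the structure. For the measured compounds named here, no step between measured compounds is known that would show how moving the nitrile around the phenyl shifts the number, and the single value of compound 2 gives no direction to lean on.

The expectation for compound 3 is therefore a value close to compound 2, with the step of a 1.1-fold higher number from compound 2 to compound 3 (0.03 log units; within the scatter) expected to stay within the usual scatter. On that basis compound 3 is estimated at 45000 nM, with a range from 18000 nM to 110000 nM, and a fair chance that this assay returns only a limit rather than a number.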

Compound 3, half-maximal inhibitory concentration: 38600 nM
Compound 3: the middle estimate sits 1.2-fold (0.07 log units) above what was measured; measured number inside the range.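

In this assay the exchange of 4-cyanophenyl for 2-cyanophenyl on the aromatic nitrogen gives a 1.1-fold lower number from compound 2 to compound 3 (0.04 log units; within the scatter) and so leaves the two isomers indistinguishable on this read-out. Among the compounds shown here, this is the first readable step, and it shows that these two placements of the nitrile on the phenyl give no discernible difference in the number, with both compounds remaining weakly cytotoxic. Nothing at hand offers an explanation for this outcome, so the step stands as an observation only.

Compound 1, with the nitrile elsewhere on the phenyl, gives "not determined" (no result reported) and therefore adds no comparison, so the picture for the nitrile rests on a single pair. Whether an amine or a chlorine atom in place of the nitrile would shift the number beyond the scatter stays open, as does the effect of any change to the shared core, and the compounds shown cannot say whether this phenyl matters at all for the cytotoxicity seen in this assay.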